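This account rests on a few compounds, and the source may have more. Where it says the series, first, only, none or still open, it means among the compounds named here.

Working notes on the series. Three compounds of the shared core have numbers. Compound 1 `CCc1cccc2c(OC)c(-c3occ(C)c3C(=O)OC)ccc12` gives 1.3 ug/mL in a functional assay on KBVIN cells (Homo sapiens) for cytotoxicity, read by MTT assay, with a stated time of 72 h; on this read-out lower numbers stand for an effect already at smaller amounts and higher numbers for an effect only at larger amounts of compound; compound 2 `CCOC(=O)c1c(C)coc1-c1ccc2c(CC)cccc2c1OC` gives 1.8 ug/mL and compound 3 `CCOc1c(-c2occ(C)c2C(=O)OC)ccc2c(CC)cccc12` gives 1.7 ug/mL. Compound 3 stands second highest of the three numbers; a 1.3-fold higher number from compound 1 to compound 3 (0.12 log units; within the scatter) separates it from compound 1, and its gap to compound 2 is within the scatter. Compound 4 `CCOc1c(-c2occ(C)c2COC(C)=O)ccc2c(CC)cccc12` has not been measured; it carries acetoxymethyl in place of methoxycarbonyl on an aromatic carbon. Among the compounds with values here, no measured step alters this group: a 1.4-fold higher number from compound 1 to compound 2 (0.14 log units; within the scatter) and a 1.3-fold higher number from compound 1 to compound 3 (0.12 log units; within the scatter) concern only a methyl added on the ester or the ether chain, both within the scatter. They give no guide to an ester turned round, so the expectation is no step beyond the scatter, with a wide range. Compound 4 is expected at 2 ug/mL, between 0.8 ug/mL and 5 ug/mL, an estimated step of a 1.2-fold higher number from compound 3 to compound 4 (0.07 log units; within the scatter).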

Compound 4, concentration for half-maximal effect: 5.8 ug/mL
Compound 4: the middle estimate sits 2.9-fold (0.46 log units) below what was measured, and the stated range ends below it.
By their numbers in this assay, from the lowest: compounds 1, 3 and 2 (each within the scatter of the next); then compound 4.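

Within the data shown here, with acetoxymethyl in place of methoxycarbonyl, a 3.4-fold higher number from compound 3 to compound 4 (0.53 log units; beyond the scatter) in this assay is the first step beyond the scatter, though a modest one. This aromatic carbon therefore responds to a change in the ester itself, whereas the methyl added on the ester or the ether chain left the numbers within the scatter. Nothing at hand explains the step.

Still open, from the compounds shown here alone, is whether a carboxylic acid, a hydroxymethyl or an amide on this carbon would read like compound 3 or compound 4. Also open, going by these compounds, is whether a longer acyloxymethyl chain would shift the number further.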